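Inverting both stereocentres of compound 2

The compounds below may be only part of what the source reports. "The series", "measured", "known", "first", "only" and "open" are said of these compounds alone.

- Compound 1 `N#Cc1cnc(NCc2cnccc2C(F)(F)F)cc1N[C@H]1C[C@@H](O)C1` gives 90% in the test below
- Compound 2 `N#Cc1cnc(NCc2cnccc2C(F)(F)F)cc1NC[C@H]1C[C@@H](O)C1` gives 84% in the same test

In an ADME assay on S9 fraction from liver (Homo sapiens) for metabolic stability, with a stated time of 1 h (on this read-out higher numbers stand for a more stable compound and lower numbers for a less stable compound), compound 2 stands within the scatter of compound 1, so the two cannot be ranked. Compound 3 `N#Cc1cnc(NCc2cnccc2C(F)(F)F)cc1NC[C@H]1C[C@H](O)C1` differs from compound 2 in configuration only, as follows: the two compounds have the same atoms and bonds and differ only in configuration as drawn: 2 of 2 stereo elements differ (all stereocentres are inverted: mirror images); a stereocentre at a saturated ring carbon is drawn s in compound 2 and r in compound 3; a stereocentre at a saturated ring carbon is drawn s in compound 2 and r in compound 3 and nothing else.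

For the measured compounds named here, the one measured step is a number 6 percentage points lower from compound 1 to compound 2 (within the scatter) and it changes the side chain, so no measured step tests configuration. The expected change is therefore no larger than the scatter, an estimated no change at the digits printed from compound 2 to compound 3 (within the scatter) with no direction favoured. Compound 3 is expected at 84% with an estimated range from 70% to 94% in this assay once measured.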

Compound 3, percent of the compound remaining: 93%
The estimate for compound 3 lay 9 percentage points below the measured number, within the range that was stated.
By their numbers in this assay, from the lowest: compounds 2, 1 and 3 (each within the scatter of the next).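

For the compounds shown here, for the first time, a step in this assay tests configuration alone, and it reads a number 9 percentage points higher from compound 2 to compound 3 (within the scatter), so no effect of configuration can be claimed for this side chain. That comparison is a clean one for a single reason: the fact that compounds 2 and 3 differ only in the configuration as drawn. The side-chain swap, now seen with the other drawn configuration as well, reads a number 3 percentage points higher from compound 1 to compound 3 (within the scatter), so (3-hydroxycyclobutyl)methyl and 3-hydroxycyclobutyl cannot be ranked here either.

Still open, going by these compounds, is whether these numbers would hold with an amine or a carboxylic acid in place of the hydroxyl group on the cyclobutyl ring, or with a longer chain on the nitrogen.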